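The source may hold more compounds than are shown below. What is called first, only, known or untested is meant among the compounds shown, and "the series" means these compounds.

Measured compounds in the series:

Compound 1, `NS(=O)(=O)c1ccc(N2N=C(c3cccc(O)c3)C[C@H]2c2ccccc2)cc1`: 77.7%
Compound 2, `NS(=O)(=O)c1ccc(N2N=C(c3cccc(O)c3)C[C@H]2c2ccc(Cl)cc2)cc1`: 51.8%
Compound 3, `NS(=O)(=O)c1ccc(N2N=C(c3cccc(O)c3)C[C@H]2c2ccc(O)cc2)cc1`: 77.7%

Read-out throughout is a functional assay on the whole organism (strain Wistar albino) for inhibition, with Rattus norvegicus as the target, read by paw edema, with stated times of 30 min and 5 h, at a dose of 0.05 mmol/kg; on this read-out higher numbers stand for more inhibition at the one dose given (going by the name of the read-out) and lower numbers for less inhibition. Compound 3 stands level with compound 1 at the digits printed, the two together giving the highest numbers of the three; the step of no change at the digits printed from compound 1 to compound 3 (within the scatter) lies within the scatter. Compound 2 is the furthest from compound 3, the step of a number 25.9 percentage points higher from compound 2 to compound 3 (beyond the scatter) lying beyond the scatter.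

The next compound, compound 4, `NS(=O)(=O)c1ccc(N2N=C(c3cccc(O)c3)C[C@H]2c2ccccc2Cl)cc1`, differs from compound 3 by 2-chlorophenyl in place of 4-hydroxyphenyl on a saturated ring carbon.

Among the compounds with values here, two measured steps bear on this change. The step of a number 25.9 percentage points lower from compound 1 to compound 2 (beyond the scatter) shows that a chloro in place of hydrogen on an aromatic carbon of this group lowered the read-out by a modest amount, and the step of a number 25.9 percentage points higher from compound 2 to compound 3 (beyond the scatter) shows the reverse gain when hydroxy replaces chloro. The step of no change at the digits printed from compound 1 to compound 3 (within the scatter) shows hydroxy and hydrogen at that carbon to be indistinguishable. Within the data shown here, the chloro in compound 4 sits as 2-chlorophenyl rather than at the position measured in compound 2, so the only chloro-bearing comparison is imperfect; still, the expectation is a drop. Compound 4 is therefore expected to give about 55% in this assay, within 40% to 72%, the estimated step being a number 22.7 percentage points lower from compound 3 to compound 4 (beyond the scatter).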

Compound 4, a percentage reported as inhibition, in the whole organism at one dose (the size of the read-out at that dose, not a potency): 70.3%
Compound 4: the middle estimate sits 15.3 percentage points below what was measured; the measured number falls inside the stated range.
By their numbers in this assay, from the lowest: compound 2; then compounds 4, 1 and 3 (each within the scatter of the next).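

In this assay, the step of a number 18.5 percentage points higher from compound 2 to compound 4 (beyond the scatter) shows that the loss seen with 4-chlorophenyl does not simply follow from chloro on this phenyl, since 2-chlorophenyl on the same saturated ring carbon separates from it beyond the scatter. The steps of a number 7.4 percentage points lower from compound 1 to compound 4 (within the scatter) and a number 7.4 percentage points lower from compound 3 to compound 4 (within the scatter) place 2-chlorophenyl within the scatter of both the unsubstituted phenyl and 4-hydroxyphenyl, so among these four compounds only compound 2 stands apart, and 2-chlorophenyl, with no hydrogen-bond donor, stays within the scatter of the 4-hydroxyphenyl compound. Nothing measured here explains why the two chloro placements differ.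

Still open, as far as these compounds go, is how other groups on this phenyl would read, such as a methoxy, an amine or a carboxylic acid, and whether a second chloro would follow 2-chlorophenyl or 4-chlorophenyl. With one dose, these percentages also give the size of the effect at that dose and leave the potency of the four compounds unsettled.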